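Chloro in place of hydrogen on the chalcone aryl ring

A few compounds are considered here, and "the series" means these few. Any claim that something is new, unique, unknown or untested is made for them only; others in the source may bear on it.

Compound 3 `CCOC(=O)c1cc2cc(/C=C/C(=O)c3ccccc3)cc(C(C)CC)c2oc1=O` gives 10500 nM in a functional assay on KB cells (Homo sapiens) for cytotoxicity, read by sulforhodamine B assay, with a stated time of 48 h (on this read-out higher numbers stand for weaker inhibition and lower numbers for stronger inhibition), the lowest of two numbers, while compound 2 `CCOC(=O)c1cc2cc(/C=C/C(=O)c3ccc(C)cc3)cc(C(C)CC)c2oc1=O` gives 18000 nM; the step of a 1.7-fold lower number from compound 2 to compound 3 (0.23 log units; within the scatter) lies within the scatter. Compound 1 `CCC(C)c1cc(/C=C/C(=O)c2ccc(Cl)cc2)cc2cc(C(C)=O)c(=O)oc12`, which carries a chloro group on a different core, is recorded as "not active" (no number reported). Compound 4 `CCOC(=O)c1cc2cc(/C=C/C(=O)c3ccc(Cl)cc3)cc(C(C)CC)c2oc1=O` differs from compound 3 by chloro in place of hydrogen on an aromatic carbon, para to a large group on the six-membered aromatic ring of carbon only. Only the methyl-to-hydrogen step on that ring speaks to this change, and it stayed within the scatter, so no step beyond the scatter is expected in this assay. For compound 4 a value of 12000 nM is estimated, within 4000 nM to 35000 nM, an expected step of a 1.1-fold higher number from compound 3 to compound 4 (0.06 log units; within the scatter).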

Compound 4, half-maximal inhibitory concentration: 14300 nM
Compound 4: middle estimate off by 1.2-fold (0.08 log units), on the low side, within the range that was stated.
By their numbers in this assay, from the lowest: compounds 3, 4 and 2 (each within the scatter of the next).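

In this assay, chloro in place of hydrogen gives a 1.4-fold higher number from compound 3 to compound 4 (0.13 log units; within the scatter), and chloro in place of methyl gives a 1.3-fold lower number from compound 2 to compound 4 (0.10 log units; within the scatter). Hydrogen, methyl and chloro on this aromatic carbon, para to a large group, therefore cannot be told apart on this read-out, whereas the earlier compounds compared only hydrogen and methyl. No measured evidence here bears on this result. As far as these compounds go, whether an amine, a methoxy group or a carboxylic acid at this place would give a step beyond the scatter remains open.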